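The compounds below may be only part of what the source reports. "The series", "measured", "known", "first", "only" and "open" are said of these compounds alone.

Measured compounds:
- compound 1 `CCN(Cc1cccs1)C(=O)COc1ccc(C(C)C)cc1`: 397 nM
- compound 2 `CCN(Cc1cccs1)C(=O)COc1ccc(F)cc1`: 422 nM
- compound 3 `CCN(Cc1cc[nH]c1)C(=O)COc1ccc(C)cc1`: 21800 nM

In an assay on HEK293 cells for agonist activity at transient receptor potential cation channel subfamily M member 8 (Homo sapiens), read by fluorescence and calcium flux, with a stated time of 15 min (on this read-out lower numbers stand for an effect already at smaller amounts and higher numbers for an effect only at larger amounts of compound), compound 3 gives 21800 nM, the highest number of the three, far beyond the scatter from compound 2 and from compound 1. Compound 4 `CCN(Cc1ccncc1)C(=O)COc1ccc(C)cc1` is not yet measured. It differs from compound 3 in one place: pyridin-4-yl in place of 1H-pyrrol-3-yl on a saturated chain carbon bound to an amide-type nitrogen. Within the data shown here, the only measured single-place step, a 1.1-fold higher number from compound 1 to compound 2 (0.03 log units; within the scatter), changes a substituent on an aromatic carbon and so says nothing about exchanging the ring on the saturated chain carbon bound to the amide-type nitrogen. Compounds 1 and 2 differ from compound 3 in more than one place, so their much lower numbers cannot be tied to that ring alone. The expectation for compound 4 therefore rests on weak ground: the number is estimated to fall somewhat, by a 3.6-fold lower number from compound 3 to compound 4 (0.56 log units; beyond the scatter), with wide uncertainty. Compound 4 is expected at about 6000 nM in this assay, within 1200 nM to 30000 nM.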

Compound 4, half-maximal effective concentration: "not active" (no number reported)
For compound 4 the study gives words and no number; no gap can be computed for the estimate.
By their numbers in this assay, from the lowest: compounds 1 and 2 (each within the scatter of the next); then compound 3.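

Among these compounds, compound 4 is reported only in words, as "not active", so no step from compound 3 to compound 4 can be read. No measured evidence here accounts for that result. The compounds shown leave open how exchanging the ring on the saturated chain carbon alone changes the number.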